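Amine side-group notes: from compound 3 to compound 4

This account rests on a few compounds, and the source may have more. Where it says the series, first, only, none or still open, it means among the compounds named here.

Values in a functional assay on A549 cells (Homo sapiens) for antiproliferative activity, read by MTT assay, with a stated time of 72 h; on this read-out lower numbers stand for stronger inhibition and higher numbers for weaker inhibition:
- compound 1 `N=C(NC(=N)NC1CCCC1)Nc1ccc(C(F)(F)F)cc1`: 1800 nM
- compound 2 `CC(C)NC(=N)NC(=N)Nc1ccc(C(F)(F)F)cc1`: 3600 nM
- compound 3 `CC(C)CNC(=N)NC(=N)Nc1ccc(C(F)(F)F)cc1`: 1300 nM

Compound 3 at 1300 nM and compound 1 at 1800 nM lie within the scatter of each other, as a 1.4-fold lower number from compound 1 to compound 3 (0.14 log units; within the scatter) shows. Compound 3 stands clear of compound 2, with a 2.8-fold lower number from compound 2 to compound 3 (0.44 log units; beyond the scatter). The other measured step, a 2.0-fold higher number from compound 1 to compound 2 (0.30 log units; within the scatter), stays within the scatter.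

Compound 4 `CCN(C)C(=N)NC(=N)Nc1ccc(C(F)(F)F)cc1` is not yet measured. In it, ethyl(methyl)amino replaces isobutylamino on a carbon with a double bond to nitrogen (ethyl(methyl)amino in place of isobutylamino on a carbon with a double bond to nitrogen). Going by the values given here, no measured compound carries ethyl(methyl)amino, so the series offers no direct precedent. Among the compounds with values here, the closest guide is compound 2, since a 2.8-fold lower number from compound 2 to compound 3 (0.44 log units; beyond the scatter) is the only measured step beyond the scatter and it marks a sensitivity to replacing isobutyl. The modest size of that step sets the expectation here, and isobutyl now leaves rather than enters. A step of similar size toward a higher number is therefore expected in this assay, estimated as a 2.7-fold higher number from compound 3 to compound 4 (0.43 log units; beyond the scatter). Compound 4 is estimated at 3500 nM, with an expected range from 1300 nM to 9000 nM.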

Compound 4, half-maximal inhibitory concentration: 4100 nM
The estimate for compound 4 lay 1.2-fold (0.07 log units) below the measured number; the range from low to high includes it.
By their numbers in this assay, from the lowest: compounds 3, 1, 2 and 4 (each within the scatter of the next, the first and the last beyond it).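

In this assay, going by these compounds alone, ethyl(methyl)amino is the only group at this place with 0 hydrogen-bond donors, and it gives a 3.2-fold higher number from compound 3 to compound 4 (0.50 log units; beyond the scatter) and a 2.3-fold higher number from compound 1 to compound 4 (0.36 log units; beyond the scatter), while a 1.1-fold higher number from compound 2 to compound 4 (0.06 log units; within the scatter) leaves compound 4 and compound 2 not separable. The position therefore accepts a fully substituted amine nitrogen without a step beyond the scatter from the isopropylamino compound, so the step away from isobutylamino is not unique to the loss of the donor and may equally track the change of chain. The change from isobutylamino alters two counted features together, with 5 heavy atoms and 1 hydrogen-bond donor leaving and 4 heavy atoms and 0 hydrogen-bond donors entering, and no measurement on hand accounts for the difference in these numbers.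

The compounds shown leave open whether isobutyl(methyl)amino, which would keep the isobutyl chain and lose the donor, would stay with compound 3 or move toward compound 4. They also leave open how a longer chain such as n-hexylamino, or a ring amine such as pyrrolidine or morpholine, would read at this place.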